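Dropping One Chloro Group: What Compound 3 Might Show

The source may hold more compounds than are shown below. What is called first, only, known or untested is meant among the compounds shown, and "the series" means these compounds.

Of the compounds shown here, two have so far been tested in a functional assay on MDA-MB-231 cells (Homo sapiens) for cytotoxicity, read by sulforhodamine B assay, with a stated time of 48 h; on this read-out higher numbers stand for lower toxicity in this test and lower numbers for higher toxicity in this test. Compound 1 `ClCc1ccc(Cn2cnc3c(Cl)ncnc32)cc1` gives 8700 nM in this assay. Compound 2 `ClCc1ccccc1Cn1cnc2c(Cl)nc(Cl)nc21` gives 3980 nM in this assay. Among these two numbers compound 2 stands lowest, and its only neighbour, compound 1, lies beyond the usual scatter above it. Compound 1 and compound 2 differ from each other in more than one place. Within the data shown here, no single step links their two values.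

Compound 3 `ClCc1ccccc1Cn1cnc2c(Cl)ncnc21` has not yet been measured. It differs from compound 2 in one place only: hydrogen in place of chloro on an aromatic carbon. The remaining chloro group and the chloromethyl-bearing benzyl part are kept unchanged. Among the measured compounds shown here, no pair of measured compounds shows the effect of this particular change, so the size of the step cannot be read from the data at hand. The step of a 1.5-fold higher number from compound 2 to compound 3 (0.18 log units; within the scatter) is expected to be modest and, if anything, toward a higher number. Compound 3 is therefore estimated at 6000 nM, with a range from 2500 nM to 14000 nM.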

Compound 3, concentration lethal to 50% of the cells: 45700 nM
Compound 3: middle estimate off by 7.6-fold (0.88 log units), on the low side; the whole stated range lies below it.
By their numbers in this assay, from the lowest: compound 2; then compound 1; then compound 3.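

The chloro group on the aromatic carbon between two ring nitrogen atoms turns out to matter strongly in this assay: replacing it with hydrogen gives an 11-fold higher number from compound 2 to compound 3 (1.06 log units; beyond the scatter) and so moves the series toward lower toxicity in this test. Among these compounds, this is the first single-place step, since the earlier pair differed in more than one place and could not isolate the contribution of any one group; here, the chloro group at this carbon is tied directly to a large part of the activity of compound 2, with the other chloro group and the chloromethyl-bearing benzyl part unchanged. No measurement available here accounts for the size of this step.

Hydrogen is the only replacement for this chloro group among the compounds shown, so it remains open whether an amine or a methoxy group on the same carbon would give a number closer to that of compound 2 or that of compound 3. The step is also seen on a single background, which leaves open whether it would recur with the chloromethyl group placed as in compound 1.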